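Adding a Methoxy Group to a Weak Growth Inhibitor

The source may report more compounds than this note shows. Statements on the series, on what has been measured and on what is new or still open speak of the compounds shown alone.

The measured compounds so far:
Compound 1 `C=C(C)[C@@H]1CC=C(Cn2cc(COc3cccc(C4NC(=O)NC(C)=C4C(=O)OCC)c3)nn2)CC1`: 42500 nM
Compound 2 `C=C(C)[C@@H]1CC=C(Cn2cc(COc3ccc(C4NC(=O)NC5=C4C(=O)CC(C)(C)C5)cc3)nn2)CC1`: > 100000 nM
Compound 3 `C=C(C)[C@@H]1CC=C(Cn2cc(COc3cccc(C4NC(=O)NC5=C4C(=O)CC(C)(C)C5)c3)nn2)CC1`: 31000 nM

All three were tested in a functional assay on MCF7 cells (Homo sapiens) for inhibition, read by sulforhodamine B assay, with a stated time of 48 h; on this read-out lower numbers stand for stronger inhibition of growth and higher numbers for weaker inhibition of growth. Compound 1 gives 42500 nM. Compound 3 gives 31000 nM. These two numbers lie within the usual scatter of each other, so no difference between them can be claimed.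

Compound 2 stands apart: its result of > 100000 nM is a limit of the assay, not a number. Compound 2 therefore sits at the limit of > 100000 nM in this assay, at which 1 of the 3 values shown sits, the weakest end of what this assay can report.

Compound 4 `C=C(C)[C@@H]1CC=C(Cn2cc(COc3ccc(C4NC(=O)NC5=C4C(=O)CC(C)(C)C5)cc3OC)nn2)CC1` is built from compound 2 by a single change, (methoxy in place of hydrogen on an aromatic carbon). Nothing among the measured compounds shows how such a change affects this assay, and no cause can be given from these data. With compound 2 already at the limit, compound 4 is expected to remain very weak. The expected step is a number no higher from compound 2 to compound 4 (the limit leaves the size open), one that does not go beyond the scatter. Compound 4 is therefore estimated at 100000 nM, with a range from 35000 nM to 300000 nM, and a fair chance that only a limit is reported again.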

Compound 4, concentration for total growth inhibition: 91900 nM
Compound 4: middle estimate off by 1.1-fold (0.04 log units), on the high side; low and high end bracket the measured number.
By their numbers in this assay, from the lowest: compounds 3 and 1 (each within the scatter of the next); then compound 4. At a limit, above all of these: compound 2.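

In this assay, methoxy in place of hydrogen on an aromatic carbon, ortho to a large group and meta to a large group, gives an at least 1.0-fold lower number from compound 2 to compound 4 (0.03 log units; that floor lies within the scatter). This is the first view of such a change among these compounds, and compound 4 gives an actual number, 91900 nM, so the methoxy compound can be placed on the scale of the assay. Compound 2 has only a limit of the assay, not a number: the limit of > 100000 nM in this assay, at which 1 of the 4 values shown sits.

On these data alone, the true size of the step stays open, and a floor within the scatter does not establish any real gain from methoxy. Also open, as far as these compounds go, is whether an amine, a carboxylic acid or a longer chain at the same place would shift the number any further, and whether methoxy would act alike on compound 3.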